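Benzyl Replaced by Hydrogen: What to Expect

A few compounds are considered here, and "the series" means these few. Any claim that something is new, unique, unknown or untested is made for them only; others in the source may bear on it.

In a functional assay on U-87MG ATCC cells for cytotoxicity against U-87 MG (Homo sapiens), read by colorimetric assay and MTT assay (a lower number here means a stronger inhibitor, a higher number a weaker inhibitor), compound 1 `COc1ccc(-c2cc3c(OC)cc(OC)cc3n(CCCC#N)c2=O)cc1` gives 10000 nM as its reading, and compound 2 `COc1ccc(-c2cc3c(OC)cc(OC)cc3n(CC(=O)OCc3ccccc3)c2=O)cc1` gives 10000 nM as its reading, so compound 2 stands level with compound 1. Compound 3 `COc1ccc(-c2cc3c(OC)cc(OC)cc3n(CC(=O)O)c2=O)cc1` differs from compound 2 by a single change (hydrogen in place of benzyl on an oxygen next to a carbonyl group), which reads benzyloxycarbonyl to carboxy. Among the measured compounds shown here, one measured step bears on this, benzyloxycarbonyl in place of 2-cyanoethyl, and it amounted to no change at the digits printed from compound 1 to compound 2 (within the scatter) in this assay with no movement in either direction. For the measured compounds named here, that step is only indirect guidance, since no measured pair tests the loss of benzyl itself. The step expected is no change at the digits printed from compound 2 to compound 3 (within the scatter) with no direction favoured, so nothing beyond the scatter is anticipated. For compound 3 the estimated value is 10000 nM (expected range 4000 nM to 30000 nM).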

Compound 3, half-maximal inhibitory concentration: 10000 nM
Compound 3: the middle estimate sits on the measured number at the digits printed; the range from low to high includes it.
By their numbers in this assay, from the lowest: compounds 1, 2 and 3 (each within the scatter of the next).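

Taking benzyl off the oxygen next to a carbonyl group gave no change at the digits printed from compound 2 to compound 3 (within the scatter) in this assay and so removed 7 heavy atoms and a six-membered aromatic ring without any shift in the reading. Carboxy in place of 2-cyanoethyl on the saturated chain carbon bound to an aromatic nitrogen likewise gave no change at the digits printed from compound 1 to compound 3 (within the scatter) and added a third group at this position that shares the reading of the other two. Nothing available explains why these groups read alike.

Going by these compounds, it remains open whether an amine or an amide on this chain, or a longer chain ending in carboxy, would depart from this shared reading. The compounds shown also leave open whether any group at this position can bring a stronger reading in this assay at all.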